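Methoxy shift in the series: compound 3 to compound 4

The compounds below may be only part of what the source reports. "The series", "measured", "known", "first", "only" and "open" are said of these compounds alone.

In a functional assay on HeLa cells (Homo sapiens) for antiproliferative activity, with a stated time of 48 h (a higher number here means a weaker inhibitor, a lower number a stronger inhibitor), compound 1 `C=C(Br)C(=O)Nc1ccc(/C=C/C(=O)c2ccccc2)cc1` gives 3900 nM, compound 2 `C=C(Br)C(=O)Nc1ccc(/C=C/C(=O)c2ccc(Br)cc2)cc1` gives 1000 nM and compound 3 `C=C(Br)C(=O)Nc1ccc(/C=C/C(=O)c2ccc(OC)cc2)cc1` gives 1400 nM. Compound 3 cannot be separated from compound 2 (a 1.4-fold higher number from compound 2 to compound 3 (0.15 log units; within the scatter)), but it lies beyond the scatter from compound 1 (a 2.8-fold lower number from compound 1 to compound 3 (0.44 log units; beyond the scatter)).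

Compound 4 `C=C(Br)C(=O)Nc1ccc(/C=C/C(=O)c2cccc(OC)c2)cc1` carries 3-methoxyphenyl in place of 4-methoxyphenyl on a carbonyl carbon. Within the data shown here, no measured step shows such a shift. The nearest evidence is the modest gain on adding methoxy, a 2.8-fold lower number from compound 1 to compound 3 (0.44 log units; beyond the scatter), alongside the bromo step, a 3.9-fold lower number from compound 1 to compound 2 (0.59 log units; beyond the scatter).

A small rise within the scatter is expected, estimated as a 1.3-fold higher number from compound 3 to compound 4 (0.11 log units; within the scatter). Compound 4 is estimated at 1800 nM, with an expected range of 800 nM to 4000 nM.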

Compound 4, half-maximal inhibitory concentration: 700 nM
Beside the measured number, compound 4's estimate is 2.6-fold (0.41 log units) above it, outside the stated range (below it).
By their numbers in this assay, from the lowest: compounds 4, 2 and 3 (each within the scatter of the next); then compound 1.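

In this assay, moving the methoxy so that 3-methoxyphenyl replaces 4-methoxyphenyl on a carbonyl carbon gives no separable change: a 2.0-fold lower number from compound 3 to compound 4 (0.30 log units; within the scatter). The exchange of 4-bromophenyl for 3-methoxyphenyl is likewise unresolved, a 1.4-fold lower number from compound 2 to compound 4 (0.15 log units; within the scatter), while the step from the unsubstituted phenyl stands clear of the scatter, a 5.6-fold lower number from compound 1 to compound 4 (0.75 log units; beyond the scatter). No measurement here accounts for these numbers.

Going by these compounds, whether other groups on that ring would hold the level of compound 4 stays open, for instance an amine, a carboxylic acid or a longer alkoxy chain in place of the methoxy.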